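Hydroxy to methoxy on compound 2: working notes

The compounds below may be only part of what the source reports. "The series", "measured", "known", "first", "only" and "open" are said of these compounds alone.

Measured so far in a functional assay on HaCaT cells (Homo sapiens) for inhibition, read by sulforhodamine B assay, with a stated time of 48 h; a higher number here means a weaker inhibitor of growth, a lower number a stronger inhibitor of growth
- compound 1 `COc1ccc(/C=C/C2(C)C=CC(=O)O2)cc1OC` gives 838000 nM
- compound 2 `CC1(/C=C/c2cccc(O)c2)C=CC(=O)O1` gives 88100 nM

Compound 2 holds the lower of the two numbers, which makes it the stronger inhibitor of growth of this pair, and the gap to compound 1 lies beyond the scatter. For the measured compounds named here, no step between two measured compounds that differ in one place is available yet, so any expectation rests on little.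

Compound 3 `COc1cccc(/C=C/C2(C)C=CC(=O)O2)c1` is next to be read in this assay. Its structure departs from that of compound 2 by methyl in place of hydrogen on an oxygen on an aromatic ring (methyl in place of hydrogen on an oxygen on an aromatic ring, hydroxy to methoxy).

Compound 1 also carries methoxy and no hydroxy, and it gives 838000 nM, so a move towards that number is expected. The expected direction is upward, towards weaker inhibition, and the estimated size is a 3.2-fold higher number from compound 2 to compound 3 (0.50 log units; beyond the scatter), beyond the scatter but short of the full gap between the measured pair. The estimated value for compound 3 is 280000 nM, with an expected range from 80000 nM to 900000 nM.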

Compound 3, concentration for total growth inhibition: 5700 nM
Compound 3: the middle estimate sits 49-fold (1.69 log units) above what was measured; the whole stated range lies above it.
By their numbers in this assay, from the lowest: compound 3; then compound 2; then compound 1.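

In this assay, for the compounds shown here, the change of hydroxy to methoxy gives a 15-fold lower number from compound 2 to compound 3 (1.19 log units; beyond the scatter) and so a stronger inhibitor of growth, which is the first direct reading of this change on an oxygen on an aromatic ring and runs opposite to the comparison of compound 1 with compound 2, where the two compounds differ in more than one place. The step of hydrogen in place of methoxy on an aromatic carbon gives a 150-fold lower number from compound 1 to compound 3 (2.17 log units; beyond the scatter) in the same assay, so the weak number of compound 1 does not follow from the presence of methoxy as such: compound 3 also carries methoxy and has the lowest number of the three. Nothing on hand gives a reason for the size or direction of either step.

Open, going by these compounds, is whether the gain stops at the methyl or continues with a longer chain on the same oxygen, such as ethoxy. Also open, on these data alone, is how an amine would read in place of the methoxy of compound 3, and whether the large loss seen with the added methoxy of compound 1 would recur with another group, such as fluoro, on that aromatic carbon.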